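The source may report more compounds than this note shows. Statements on the series, on what has been measured and on what is new or still open speak of the compounds shown alone.

In a functional assay on A549 cells (Homo sapiens) for antiproliferative activity, read by CCK-8 assay, with a stated time of 72 h (on this read-out lower numbers stand for stronger inhibition and higher numbers for weaker inhibition), compound 1 (`Nc1ccccc1NC(=O)/C=C/c1ccc(CSc2ccc(F)cc2)cc1`) reads 1190 nM while compound 2 (`Cc1ccc(SCc2ccc(C(=O)Nc3ccccc3N)cc2)cc1`) reads 3270 nM and compound 3 (`COc1ccc(SCc2ccc(C(=O)Nc3ccccc3N)cc2)cc1OC`) reads 5680 nM in this small set. Compound 2 thus holds the middle number, within the scatter of compound 3 and beyond the scatter above compound 1. The step to compound 4 (`Cc1cc(C)cc(SCc2ccc(C(=O)Nc3ccccc3N)cc2)c1`) puts 3,5-dimethylphenyl in place of 4-methylphenyl on a sulfur. For the measured compounds named here, no step between measured compounds isolates this change. Compound 3 at 5680 nM and compound 2 at 3270 nM lie within the scatter of each other with different groups on that sulfur, so this assay is expected to show no step beyond the scatter. The estimate means a 1.2-fold higher number from compound 2 to compound 4 (0.07 log units; within the scatter) as the expected change. Compound 4 is expected at 3800 nM (estimated range 1700 nM to 8000 nM).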

Compound 4, half-maximal inhibitory concentration: 2890 nM
Compound 4: middle estimate off by 1.3-fold (0.12 log units), on the high side, and the stated range covers the measured number.
By their numbers in this assay, from the lowest: compound 1; then compounds 4, 2 and 3 (each within the scatter of the next).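

In this assay, for the compounds shown here, the swap of 4-methylphenyl for 3,5-dimethylphenyl on a sulfur gives a 1.1-fold lower number from compound 2 to compound 4 (0.05 log units; within the scatter) and is the only step that isolates this position, where it lies within the scatter. The two compounds of this pair cannot be told apart on this read-out, so the second methyl group on that ring has no resolved effect here. No measurement bearing on an explanation accompanies this result. The compounds shown leave open whether an amine or a carboxylic acid on that aromatic ring, or a longer chain in its place on the sulfur, would give a step beyond the scatter.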